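Ester Side-Chain Variation and Cytotoxicity in Three Quinolinones

The source may hold more compounds than are shown below. What is called first, only, known or untested is meant among the compounds shown, and "the series" means these compounds.

Measured compounds:
compound 1, `CC(C)C(=O)OCCc1c(-c2ccccc2Cl)c2cc(Cl)ccc2[nH]c1=O`, 62000 nM
compound 2, `CCOCC(=O)OCCc1c(-c2ccccc2Cl)c2cc(Cl)ccc2[nH]c1=O`, 130000 nM
compound 3, `O=C(COc1ccccc1)OCCc1c(-c2ccccc2Cl)c2cc(Cl)ccc2[nH]c1=O`, 81000 nM

In an ADME assay on HepG2 2.2.15 cells (Homo sapiens) for cytotoxicity (on this read-out lower numbers stand for higher toxicity in this test and higher numbers for lower toxicity in this test), compound 3 stands second highest of the three numbers, within the scatter of both compound 1 and compound 2. Compound 4, `C/C=C/C(=O)OCCc1c(-c2ccccc2Cl)c2cc(Cl)ccc2[nH]c1=O`, differs from compound 3 only at the ester carbonyl: prop-1-en-1-yl in place of phenoxymethyl on a carbonyl carbon. Among the compounds with values here, the steps that bear on this change all alter the same acyl group. The step of a 1.3-fold higher number from compound 1 to compound 3 (0.12 log units; within the scatter) and the step of a 1.6-fold lower number from compound 2 to compound 3 (0.21 log units; within the scatter) lie within the scatter, while a 2.1-fold higher number from compound 1 to compound 2 (0.32 log units; beyond the scatter) is modest. Exchanging one acyl group for another has therefore moved this read-out little, so compound 4 is expected to show no step beyond the scatter, a 1.2-fold lower number from compound 3 to compound 4 (0.06 log units; within the scatter). Compound 4 is estimated at 70000 nM, with a range from 35000 nM to 140000 nM.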

Compound 4, half-maximal cytotoxic concentration: 30000 nM
Beside the measured number, compound 4's estimate is 2.3-fold (0.37 log units) above it; measured number below the stated range.
By their numbers in this assay, from the lowest: compound 4; then compounds 1, 3 and 2 (each within the scatter of the next, the first and the last beyond it).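

On this carbonyl carbon, where acyl exchange had previously given only steps within the scatter or a modest one, prop-1-en-1-yl separates compound 4 from all three other esters in this assay (a 2.7-fold lower number from compound 3 to compound 4 (0.43 log units; beyond the scatter)), (a 4.3-fold lower number from compound 2 to compound 4 (0.64 log units; beyond the scatter)) and (a 2.1-fold lower number from compound 1 to compound 4 (0.32 log units; beyond the scatter)). Within the data shown here, compound 4 is therefore the only compound here whose steps to all the others lie beyond the scatter, and it sits on the side of higher toxicity in this test. Nothing available accounts for this difference. Going by these compounds, whether the double bond itself matters stays open. So does how a propyl chain, an amine or a carboxylic acid at this position would read.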